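Thiophene in Place of Furan on the Shared Core

This account rests on a few compounds, and the source may have more. Where it says the series, first, only, none or still open, it means among the compounds named here.

Compound 2 `CC1=C(C(=O)OC2CCC2)C(c2ccco2)NC(=O)N1` gives 95.1 nM in an assay on membranes from HEK293 cells for displacement of a labelled ligand from adenosine receptor A2b (Homo sapiens), read by scintillation counting, with a stated time of 30 min (on this read-out higher numbers stand for weaker inhibition and lower numbers for stronger inhibition), and stands lowest of the three numbers shown, though the step of a 1.5-fold higher number from compound 2 to compound 3 (0.16 log units; within the scatter) lies within the scatter. Compound 3 `CC1=C(C(=O)OCC2CC2)C(c2ccco2)NC(=O)N1` gives 138 nM. Compound 1 `CC1=C(C(=O)CC(C)C)C(c2ccsc2)NC(=O)N1` carries thiophen-3-yl but differs from compound 2 in a second place as well. In this assay compound 1 gives 1000 nM; only the two values can be set side by side. Compound 4 `CC1=C(C(=O)OC2CCC2)C(c2ccsc2)NC(=O)N1` differs from compound 2 by thiophen-3-yl in place of furan-2-yl on a saturated ring carbon. Going by the values given here, no measured step isolates this exchange, and the one measured step concerns the group of 7 heavy atoms instead. Compound 4 is therefore expected to show a modest step of a 2.1-fold higher number from compound 2 to compound 4 (0.32 log units; beyond the scatter) toward a higher number, estimated at 200 nM with a range of 60 nM to 700 nM.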

Compound 4, inhibition constant: 405 nM
Beside the measured number, compound 4's estimate is 2.0-fold (0.31 log units) below it; the measured number falls inside the stated range.
By their numbers in this assay, from the lowest: compounds 2 and 3 (each within the scatter of the next); then compound 4; then compound 1.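

In this assay, going by these compounds alone, thiophen-3-yl in place of furan-2-yl on a saturated ring carbon, with cyclobutyloxy held fixed, gives a 4.3-fold higher number from compound 2 to compound 4 (0.63 log units; beyond the scatter) and this is the only reading that isolates the exchange at this position. Cyclobutyloxy in place of isobutyl on a carbonyl carbon, with thiophen-3-yl held fixed, gives a 2.5-fold lower number from compound 1 to compound 4 (0.39 log units; beyond the scatter) and so shows that the second place on the shared core moves the number as well. Nothing at hand explains either step. On these data alone, whether phenyl or thiophen-2-yl on that ring carbon would move the number in the same direction stays open, as does whether the exchange holds with cyclopropylmethyl on the oxygen.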